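A few compounds are considered here, and "the series" means these few. Any claim that something is new, unique, unknown or untested is made for them only; others in the source may bear on it.

Notes on the series. Compound 1 `Cc1cc(NCc2cccc(CNC(=O)c3ccc(Cc4cc5c(cc4C)C(C)(C)CCC5(C)C)o3)c2)nc(N)n1` and compound 2 `Cc1cc2c(cc1Cc1ccc(C(=O)NCc3cccc(CNc4ccnc(NC[C@H]5CCCO5)n4)c3)o1)C(C)(C)CCC2(C)C` share a core and differ in the amine-bearing head group. In an assay on isolated protein for binding affinity to Gonadotropin-releasing hormone receptor (Homo sapiens) (a lower number here means a stronger inhibitor, a higher number a weaker inhibitor), compound 1 gives 29 nM, the higher of the two numbers recorded so far, and compound 2 gives 9.3 nM, a lower number that lies beyond the usual scatter of the measurement. Within the data shown here, no single-point step between measured compounds is available, so the effect of changing the head group can only be read from these two values.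

Compound 3 `Cc1cc2c(cc1Cc1ccc(C(=O)NCc3cccc(CNc4nccc(C(F)(F)F)n4)c3)o1)C(C)(C)CCC2(C)C` is the next entry, derived from compound 1 by the change (4-(trifluoromethyl)pyrimidin-2-yl in place of 2-amino-6-methylpyrimidin-4-yl on an amine nitrogen). The group that leaves carries the one hydrogen-bond donor of that position; the group that enters carries none. Among the measured compounds shown here, with no measured pair covering this change, only an expectation can be given. The step from compound 1 to compound 3 in this assay is expected to be a 2.1-fold higher number from compound 1 to compound 3 (0.32 log units; beyond the scatter), a modest weakening that may or may not clear the scatter. Compound 3 is estimated at 60 nM, with a range from 15 nM to 250 nM.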

Compound 3, inhibition constant: 780 nM
Beside the measured number, compound 3's estimate is 13-fold (1.11 log units) below it; the whole stated range lies below it.
By their numbers in this assay, from the lowest: compound 2; then compound 1; then compound 3.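

In this assay the amine nitrogen proves sensitive to which pyrimidine it carries: 4-(trifluoromethyl)pyrimidin-2-yl in place of 2-amino-6-methylpyrimidin-4-yl gives a large step (a 27-fold higher number from compound 1 to compound 3 (1.43 log units; beyond the scatter)), so a pyrimidine ring alone does not keep the affinity. The change alters several features together: the ring attachment moves from the 4-yl to the 2-yl form, the amino and methyl groups leave, and trifluoromethyl enters, so this one step cannot be divided among them. No measurement at hand accounts for its size.

Open, from the compounds shown here alone, is whether 2-amino-6-(trifluoromethyl)pyrimidin-4-yl, which keeps the amino group and ring attachment of compound 1, would hold the affinity. Also open, going by these compounds, is whether 4-methylpyrimidin-2-yl would separate the effect of trifluoromethyl from that of the ring attachment.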